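Changing one pyridine group and tracking brain protein binding

The source may hold more compounds than are shown below. What is called first, only, known or untested is meant among the compounds shown, and "the series" means these compounds.

Among the compounds with values here, only two compounds have numbers so far. In an ADME assay on brain (Rattus norvegicus) for protein binding (a lower number here means a smaller unbound share, a higher number a larger unbound share of the compound), compound 1 `Cc1cccc(-c2ccc(NC[C@H]3CC[C@]4(CC3)CN(c3cccnn3)C(=O)O4)nc2)n1` gives 0.056 as its unbound fraction, and compound 2 `O=C1O[C@]2(CC[C@H](CNc3cnn(-c4ccccc4F)c3)CC2)CN1c1cncnc1` gives 0.044 on the same read-out. These two values lie within the usual scatter of repeat measurements, so compound 1 cannot be separated from compound 2 here.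

Compound 3 `O=C1O[C@]2(CC[C@H](CNc3ccc(-c4ncccc4F)cn3)CC2)CN1c1cccnn1` keeps the core of compound 1 and changes one group: 3-fluoropyridin-2-yl in place of 6-methylpyridin-2-yl on an aromatic carbon. Within the data shown here, no measured pair shows what this swap does, so any forecast is loose. A small upward move is expected, one that stays inside the scatter, and the estimated change is a 1.2-fold higher number from compound 1 to compound 3 (0.06 log units; within the scatter) in this assay terms. For compound 3 the estimated value is 0.065 with an expected range from 0.035 to 0.12 for the coming measurement.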

Compound 3, unbound fraction: 0.052
Estimate against measurement, compound 3: 1.3-fold (0.10 log units) above; measured number inside the range.
By their numbers in this assay, from the lowest: compounds 2, 3 and 1 (each within the scatter of the next).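

Replacing 6-methylpyridin-2-yl with 3-fluoropyridin-2-yl on this aromatic carbon gives a 1.1-fold lower number from compound 1 to compound 3 (0.03 log units; within the scatter) in this assay, so this particular swap leaves compound 1 and compound 3 impossible to tell apart on this read-out. Within the data shown here, compound 1 and compound 2 differ in more than one place, so this is the first pair that isolates a single group at this position. Nothing in the data shown explains the result.

The swap exchanges one substituted pyridine for another, so it cannot separate the effect of removing the methyl from that of adding the fluorine; plain pyridin-2-yl would be needed for that. On these data alone, it also remains open whether a group of another kind at this position, such as a carboxylic acid or an amine-bearing ring, would move the unbound fraction beyond the scatter.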